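Dropping the trifluoromethyl group from compound 1

The compounds below may be only part of what the source reports. "The series", "measured", "known", "first", "only" and "open" are said of these compounds alone.

Among the compounds with values here, compound 1 `O=C(CCC1=CCN(Cc2ccc(C(F)(F)F)cc2)C1=O)NO` is one of three compounds measured in a functional assay on HCT-15 cells (Homo sapiens) for antiproliferative activity (a higher number here means a weaker inhibitor of growth, a lower number a stronger inhibitor of growth), and compound 1 gives 4540 nM. Compound 2 `COc1ccc(CN2CC=C(CCC(=O)NO)C2=O)cc1` gives 1720 nM in this assay. Compound 3 `COc1ccccc1CCCN1CC=C(CCC(=O)NO)C1=O` gives > 10000 nM in this assay, which is a limit of the assay and not a number. Among the two numbers, compound 1 stands highest, and the only single-site step recorded, a 2.6-fold lower number from compound 1 to compound 2 (0.42 log units; beyond the scatter), runs downward from it.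

Compound 4 `O=C(CCC1=CCN(Cc2ccccc2)C1=O)NO` differs from compound 1 by hydrogen in place of trifluoromethyl on an aromatic carbon. Within the data shown here, no measured step removes this group outright; the one step at the same position, a 2.6-fold lower number from compound 1 to compound 2 (0.42 log units; beyond the scatter), exchanged it for methoxy and was modest. Replacement by hydrogen is therefore expected to give at most a small change, most likely again a somewhat lower number, so that a 1.5-fold lower number from compound 1 to compound 4 (0.18 log units; within the scatter) is estimated. For compound 4 the expected value in this assay is 3000 nM, with a range from 1200 nM to 8000 nM.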

Compound 4, concentration for 50% growth inhibition: 5370 nM
Estimate against measurement, compound 4: 1.8-fold (0.25 log units) below; measured number inside the range.
By their numbers in this assay, from the lowest: compound 2; then compounds 1 and 4 (each within the scatter of the next). At a limit, above all of these: compound 3.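

Replacing trifluoromethyl with hydrogen gives a 1.2-fold higher number from compound 1 to compound 4 (0.07 log units; within the scatter) in this assay, so at this place on the aromatic ring the two groups cannot be told apart here. Methoxy does stand apart, with a 3.1-fold higher number from compound 2 to compound 4 (0.49 log units; beyond the scatter), and this places the lower number of compound 2 with methoxy itself and not merely with the loss of trifluoromethyl. No measurement shown bears on why methoxy alone separates from the other two groups at this place.

Going by these compounds, whether a hydroxyl group, an amine or a carboxylic acid at this place would follow methoxy or fall in with hydrogen and trifluoromethyl remains open. So does whether a longer ether such as ethoxy would keep the step seen with methoxy, or whether that step is particular to methoxy.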